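Phenyl added at the sulfonamide chain of compound 2

The source may hold more compounds than are shown below. What is called first, only, known or untested is meant among the compounds shown, and "the series" means these compounds.

Compounds measured so far:
compound 1 `CCN(CC)S(=O)(=O)c1cncc(-c2ccn3nc(N)nc3c2)c1`: 25100000 nM
compound 2 `CNS(=O)(=O)c1cncc(-c2ccn3nc(N)nc3c2)c1`: 39800000 nM

In an assay on isolated protein for inhibition of phosphatidylinositol 4,5-bisphosphate 3-kinase catalytic subunit beta isoform (Homo sapiens) (a lower number here means a stronger inhibitor, a higher number a weaker inhibitor), compound 1 gives 25100000 nM. Compound 2, which carries methylamino in place of diethylamino on the sulfonyl sulfur, gives in this assay a number of 39800000 nM. These two stand together: the change is a 1.6-fold higher number from compound 1 to compound 2 (0.20 log units; within the scatter), so nothing separates them beyond the usual noise, and both numbers are very large.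

Compound 3 `Nc1nc2cc(-c3cncc(S(=O)(=O)NCc4ccccc4)c3)ccn2n1` differs from compound 2 by phenyl in place of hydrogen on a saturated chain carbon bound to a sulfonamide nitrogen; cut one bond further out, the same difference reads methyl to benzyl, or methylamino to benzylamino. Going by the values given here, the only step that bears on it is the one from diethylamino to methylamino, which was a 1.6-fold higher number from compound 1 to compound 2 (0.20 log units; within the scatter). That step altered what sits on the sulfonamide nitrogen and left the number where it was. On that basis compound 3 is expected to give in this assay a number close to that of compound 2, with the expected step of a 1.2-fold lower number from compound 2 to compound 3 (0.09 log units; within the scatter) no larger than the scatter. The estimate for compound 3 is 32000000 nM, within a range of 8000000 nM to 130000000 nM.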

Compound 3, half-maximal inhibitory concentration: 25100000 nM
Compound 3: the middle estimate sits 1.3-fold (0.11 log units) above what was measured; measured number inside the range.
By their numbers in this assay, from the lowest: compounds 1, 3 and 2 (each within the scatter of the next).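

In this assay, going by these compounds alone, the earlier compounds carried only alkyl groups on the sulfonamide nitrogen, and compound 3 extends that comparison to an aromatic ring: methyl to benzyl gives a 1.6-fold lower number from compound 2 to compound 3 (0.20 log units; within the scatter) and benzylamino in place of diethylamino gives no change at the digits printed from compound 1 to compound 3 (within the scatter). Both steps lie within the scatter, so this position has now taken methylamino, diethylamino and benzylamino with no separation among the three compounds, and all three numbers stay very large. Nothing available here accounts for this reading of the position.

The compounds shown leave open whether a different kind of group on this sulfonamide nitrogen, such as a chain ending in an amine or a carboxylic acid, or a longer chain carrying the phenyl, would give a step beyond the scatter. They also leave open whether a fluorine or a methoxy group on the phenyl of compound 3, or a pyridine ring in its place, would separate from the benzylamino compound at all.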